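A few compounds are considered here, and "the series" means these few. Any claim that something is new, unique, unknown or untested is made for them only; others in the source may bear on it.

Compound 1, `Nc1scc(CN2CCN(c3cc(Cl)cc(Cl)c3)CC2)c1C(=O)c1ccc(Cl)cc1`, in a functional assay on CHO cells with adenosine receptor A1 (Homo sapiens) as the target, read by cAMP accumulation and immunoassay, with a stated time of 6 min, tested at 0.01 uM (a higher number here means a weaker effect of the compound at the concentration tested, a lower number a stronger effect), gives -1%.
Compound 2, `Nc1scc(CN2CCN(c3cccnc3)CC2)c1C(=O)c1ccc(Cl)cc1`, gives 3.2%.
Compound 3, `Nc1scc(CN2CCN(c3ccc(F)c(F)c3)CC2)c1C(=O)c1ccc(Cl)cc1`, gives -3.2%.

Compound 3 stands at the low end of these three numbers, but only on paper: the step of a number 2.2 percentage points lower from compound 1 to compound 3 (within the scatter) and the step of a number 6.4 percentage points lower from compound 2 to compound 3 (within the scatter) both lie within the scatter, so the three compounds cannot be told apart in this assay. The same holds for the step of a number 4.2 percentage points higher from compound 1 to compound 2 (within the scatter). In all three measured compounds, swapping the aryl group on the ring nitrogen has left the read-out essentially flat.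

Compound 4, `Nc1scc(CN2CCN(c3ccc(Cl)c(Cl)c3)CC2)c1C(=O)c1ccc(Cl)cc1`, is the next step from compound 3:

3,4-dichlorophenyl in place of 3,4-difluorophenyl on an amine nitrogen in a ring

The measured steps that bear on this change are the ones in which one aryl group replaced another at the same ring nitrogen, above all the step from compound 1 to compound 3, where a dichlorophenyl gave way to a difluorophenyl and nothing beyond the scatter followed. With no evidence that either a change of halogen or a change of substitution pattern moves the number, the expectation for compound 4 is a step of a number 1.2 percentage points higher from compound 3 to compound 4 (within the scatter) that stays within the scatter. Compound 4 is therefore estimated to give -2% in this assay, with a likely range from -12% to 8%.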

Compound 4, a percentage reported as activity, at one concentration (the size of the read-out at that concentration, not a potency): -1.2%
For compound 4 the middle estimate is 0.8 percentage points below the measured one; the range from low to high includes it.
By their numbers in this assay, from the lowest: compounds 3, 4, 1 and 2 (each within the scatter of the next).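

Among these compounds, replacing 3,4-difluorophenyl with 3,4-dichlorophenyl keeps the substitution pattern and alters only the halogen, a comparison no earlier pair isolated, and in this assay it gives a number 2 percentage points higher from compound 3 to compound 4 (within the scatter). The opposite comparison is now also available: keeping chlorine and going from 3,5-dichlorophenyl to 3,4-dichlorophenyl gives a number 0.2 percentage points lower from compound 1 to compound 4 (within the scatter), while the comparison with pyridin-3-yl gives a number 4.4 percentage points lower from compound 2 to compound 4 (within the scatter). Taken separately, neither the identity of the halogen nor the arrangement of the two chlorines distinguishes these compounds at the one concentration tested, and nothing available offers an explanation for this flat picture.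

The compounds shown all carry an aromatic ring on the ring nitrogen, so it remains open whether the read-out would stay flat with a benzyl group, a simple methyl group or a phenyl ring bearing a carboxylic acid or an amine. The rest of the shared core is identical throughout, and a read-out at a single concentration cannot show whether these compounds would differ in potency.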